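This account rests on a few compounds, and the source may have more. Where it says the series, first, only, none or still open, it means among the compounds named here.

Among the measured compounds shown here, in a physicochemical assay for metabolic stability, read by HPLC, in phosphate buffer, at pH 7.4 (a higher number here means that the compound lasts longer, a lower number that the compound disappears faster), three compounds have numbers so far: compound 1 (`CN(/N=N/c1ccc(C#N)cc1)C(=O)CCc1ccc(O)cc1`) gives 76 h as its half-life, compound 2 (`COC(=O)c1ccc(/N=N/N(C)C(=O)CCc2cccc(O)c2)cc1`) gives 94.7 h and compound 3 (`COC(=O)c1ccc(/N=N/N(C)C(=O)CCCCc2ccc(O)cc2)cc1`) gives 124 h on the same read-out. Compound 2 thus lies within the scatter of both of the others. Compound 4 (`CN(/N=N/c1ccc(C#N)cc1)C(=O)CCc1cccc(O)c1`) has not yet been measured. It differs from compound 2 by a single change (cyano in place of methoxycarbonyl on an aromatic carbon), cyano in place of methoxycarbonyl on an aromatic carbon, para to a large group. For the measured compounds named here, the only measured step in one place (a 1.3-fold higher number from compound 2 to compound 3 (0.12 log units; within the scatter)) lies on the chain rather than at this position and stays within the scatter, so it bears on the exchange only loosely. Compound 1 also carries cyano and reads 76 h here, though it differs from compound 2 in more than one place. No step beyond the scatter is therefore expected in this assay for this exchange. The expected step (a 1.2-fold lower number from compound 2 to compound 4 (0.07 log units; within the scatter)) is a small one. For compound 4 the estimated half-life is 80 h (expected range 45 h to 135 h).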

Compound 4, half-life: 60.1 h
Beside the measured number, compound 4's estimate is 1.3-fold (0.12 log units) above it; the measured number falls inside the stated range.
By their numbers in this assay, from the lowest: compounds 4, 1, 2 and 3 (each within the scatter of the next, the first and the last beyond it).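

In this assay, among the compounds shown here, the exchange of methoxycarbonyl for cyano on an aromatic carbon, para to a large group, now has a direct reading: a 1.6-fold lower number from compound 2 to compound 4 (0.20 log units; within the scatter), so the smaller cyano group, with its 2 heavy atoms against 4, gives no step that can be told from repeat measurements. With cyano held constant, the shift to 3-hydroxyphenyl in place of 4-hydroxyphenyl on the saturated chain carbon can also be read directly, and a 1.3-fold lower number from compound 1 to compound 4 (0.10 log units; within the scatter) likewise leaves the two compounds unseparated. Nothing available bears on why these numbers stand as they do.

Still open, from the compounds shown here alone, is whether a carboxylic acid or an amine on this aromatic carbon would give a step beyond the scatter. Going by these compounds, it is also open whether cyano and methoxycarbonyl would remain this close on a compound carrying a longer chain.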